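From tert-butyl to difluoromethoxy on a shared core

The compounds below may be only part of what the source reports. "The series", "measured", "known", "first", "only" and "open" are said of these compounds alone.

Values so far in a functional assay on MCF-10A cells (Homo sapiens) for antiproliferative activity, with a stated time of 48 h; on this read-out lower numbers stand for an effect already at smaller amounts and higher numbers for an effect only at larger amounts of compound (measured)
- compound 1 `COc1ccc2nc(C)cc(NCc3ccc(C(C)(C)C)cc3)c2c1` gives 6900 nM (measured)
- compound 2 `COc1ccc2nc(C)cc(NCc3ccccc3OC)c2c1` gives 25200 nM (measured)

Of these two numbers, compound 1 holds the lower, and the gap up to compound 2 lies beyond the usual scatter. Going by the values given here, the two compounds differ in more than one place, so no measured step exists to serve as a guide. The next compound is compound 3 `COc1ccc2nc(C)cc(NCc3ccc(OC(F)F)cc3)c2c1` (difluoromethoxy in place of tert-butyl on an aromatic carbon, para to a large group) difluoromethoxy in place of tert-butyl on an aromatic carbon and it has not yet been measured. In this assay a small rise is expected, near the edge of the scatter, and the reasoning rests on the structural change alone. The expected step is a 1.9-fold higher number from compound 1 to compound 3 (0.28 log units; within the scatter) (toward higher numbers). The estimated value for compound 3 is 13000 nM (expected range 5000 nM to 30000 nM).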

Compound 3, half-maximal effective concentration: 10400 nM
Beside the measured number, compound 3's estimate is 1.3-fold (0.10 log units) above it; measured number inside the range.
By their numbers in this assay, from the lowest: compounds 1 and 3 (each within the scatter of the next); then compound 2.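

In this assay, going by these compounds alone, the one step that changes a single place on the shared core reads a 1.5-fold higher number from compound 1 to compound 3 (0.18 log units; within the scatter). At this position, on an aromatic carbon para to a large group, replacing the all-carbon tert-butyl with difluoromethoxy, which brings in oxygen and fluorine and adds a hydrogen-bond acceptor, therefore leaves the number within the usual scatter. Nothing shown explains this outcome. Compound 2 differs from compound 1 and compound 3 in more than one place, so it adds nothing to the reading of this step.

As far as these compounds go, it remains open whether the number would also stay within the scatter with an amine, a carboxylic acid or a longer chain on this aromatic carbon. The compounds shown also leave open what a methoxy group would give at this same position.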